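This account rests on a few compounds, and the source may have more. Where it says the series, first, only, none or still open, it means among the compounds named here.

In a functional assay on CCRF-CEM cells (Homo sapiens) for antiproliferative activity, with a stated time of 72 h (a lower number here means a stronger inhibitor, a higher number a weaker inhibitor), two compounds with the same core have been measured so far. Compound 1 (`OC[C@H]1O[C@@H](n2cnc3c(NCc4ccc(F)cc4F)ncnc32)[C@H](O)[C@@H]1O`) gives 7100 nM, while compound 2 (`OC[C@H]1O[C@@H](n2cnc3c(NCc4c(F)ccc(F)c4F)ncnc32)[C@H](O)[C@@H]1O`) gives 90300 nM, the higher of the two numbers. Compound 3 (`Cc1ccc(O)c(CNc2ncnc3c2ncn3[C@@H]2O[C@H](CO)[C@@H](O)[C@H]2O)c1`) has not yet been measured. It carries 2-hydroxy-5-methylphenyl in place of 2,3,6-trifluorophenyl on a saturated chain carbon bound to a nitrogen on an aromatic ring. Within the data shown here, only one measured step bears on this place: a 13-fold higher number from compound 1 to compound 2 (1.10 log units; beyond the scatter). Among the measured compounds shown here, that large step, beyond the scatter, shows that changes here can shift the number strongly, but no measured compound carries a hydroxy group on this phenyl ring. With compound 2 at 90300 nM, the higher end of the two numbers, a move toward compound 1 is expected, of roughly similar size. The expected step is a 10-fold lower number from compound 2 to compound 3 (1.00 log units; beyond the scatter). For compound 3 the estimated value is 9000 nM, with an expected range from 1800 nM to 50000 nM.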

Compound 3, half-maximal inhibitory concentration: 1900 nM
Compound 3: the middle estimate sits 4.7-fold (0.68 log units) above what was measured, within the range that was stated.
By their numbers in this assay, from the lowest: compound 3; then compound 1; then compound 2.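

In this assay, 2-hydroxy-5-methylphenyl on a saturated chain carbon bound to a nitrogen on an aromatic ring brings a 48-fold lower number from compound 2 to compound 3 (1.68 log units; beyond the scatter), and the same change measured against the other fluorinated ring brings a 3.7-fold lower number from compound 1 to compound 3 (0.57 log units; beyond the scatter). This position therefore tolerates more than fluorinated phenyl groups: the ring without fluorine gives the lowest number of the three, beyond the scatter against both others. No available measurement accounts for this difference between the rings.

Since the hydroxy and methyl groups enter together, the compounds shown do not separate the contribution of each. Going by these compounds, it also remains open how an amine or a methoxy group in place of the hydroxy group, or a longer chain carrying the ring, would read in this assay.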